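The source may hold more compounds than are shown below. What is called first, only, known or untested is meant among the compounds shown, and "the series" means these compounds.

Measured compounds and their values in a functional assay on NCI-H2228 cells (Homo sapiens) for inhibition, read by CellTiter-Glo, with a stated time of 96 h; on this read-out higher numbers stand for weaker inhibition and lower numbers for stronger inhibition:
- compound 1 `Cc1cc(Nc2ncc(Cl)c(Nc3cn(C)nc3S(=O)(=O)C(C)C)n2)c(OC2CC2)cc1C1COC1` gives 44 nM
- compound 2 `CC(C)S(=O)(=O)c1nn(C)cc1Nc1nc(Nc2cc(C#N)c(C3CCN(C)CC3)cc2OC2CC2)ncc1Cl` gives 165 nM

Of the two numbers in hand, compound 1 gives the lower and compound 2 the higher; the gap between them lies beyond the usual scatter, so compound 1 stands as the stronger inhibitor of the pair on this read-out. For the measured compounds named here, the two compounds differ in more than one place, and no single-change step between measured compounds is available, so nothing can be said about which part of that difference carries the gap.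

Compound 3 `Cc1cc(Nc2ncc(Cl)c(Nc3cn(C)nc3S(=O)(=O)C(C)C)n2)c(OC2CC2)cc1C(=O)C(C)C` has not yet been measured in this assay. It keeps the shared core of compound 1 and differs from it in one place: isopropylcarbonyl in place of oxetan-3-yl on an aromatic carbon. Both groups that are exchanged carry one hydrogen-bond acceptor and no donor, and both are of similar size, so no large shift is expected. The step from compound 1 to compound 3 is expected to be small, toward a somewhat higher number, and may well fall within the scatter: a 1.7-fold higher number from compound 1 to compound 3 (0.23 log units; within the scatter). For compound 3 the expected value in this assay is 75 nM, with a range from 25 nM to 220 nM.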

Compound 3, half-maximal inhibitory concentration: 149 nM
For compound 3 the middle estimate is 2.0-fold (0.30 log units) below the measured one; measured number inside the range.
By their numbers in this assay, from the lowest: compound 1; then compounds 3 and 2 (each within the scatter of the next).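

In this assay, the aromatic carbon ortho to a methyl group, meta to a cyclopropyloxy group and para to a large group now has its first single-change read-out: replacing oxetan-3-yl with isopropylcarbonyl gives a 3.4-fold higher number from compound 1 to compound 3 (0.53 log units; beyond the scatter). The position therefore responds to this exchange, even though the two groups have the same counts of hydrogen-bond donors and acceptors and neither carries a net charge, so those matched counts do not guarantee a matched value here. No supporting data are available to explain the step.

The exchange removes the four-membered ring and adds a double bond outside aromatic rings, and this single step cannot show which of these changes, or the change in heavy-atom count, carries the shift. Open questions are how the series responds at this position to a cyclobutyl group, which keeps a four-membered ring without its oxygen, to an azetidin-3-yl group, which places a ring nitrogen in that ring, and to an acetyl group, which keeps the carbonyl with a shorter chain.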